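A few compounds are considered here, and "the series" means these few. Any claim that something is new, unique, unknown or untested is made for them only; others in the source may bear on it.

Compound 1 `COc1ccc([C@@H]2C/C(=N\O)c3c(O)cc(OCc4cn(CC5CC5)nn4)cc3O2)cc1O` is examined in a functional assay on RAW264.7 cells (Mus musculus) for inhibition, read by Griess assay, with stated times of 2 h and 24 h (on this read-out lower numbers stand for stronger inhibition and higher numbers for weaker inhibition), where compound 1 gives 6320 nM. Among the three measured compounds this places compound 1 second highest: its nearest neighbour is compound 2 `COc1ccc([C@@H]2C/C(=N\O)c3c(O)cc(OCc4cn(Cc5ccccc5F)nn4)cc3O2)cc1O`, which gives 5710 nM, and the furthest is compound 3 `COc1ccc([C@@H]2C/C(=N\O)c3c(O)cc(OCc4cn(Cc5ccccc5C)nn4)cc3O2)cc1O`, which gives 18000 nM. The steps between them are a 1.1-fold lower number from compound 1 to compound 2 (0.04 log units; within the scatter), a 2.8-fold higher number from compound 1 to compound 3 (0.45 log units; beyond the scatter) and a 3.2-fold higher number from compound 2 to compound 3 (0.50 log units; beyond the scatter).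

Compound 4 `C#CCOc1cc(O)c2c(c1)O[C@H](c1ccc(OC)c(O)c1)C/C2=N\O` differs from compound 1 in one place: ethynyl in place of 1-(cyclopropylmethyl)-1H-1,2,3-triazol-4-yl on a saturated chain carbon bound to an oxygen on an aromatic ring. All three measured steps vary only the substituent on the saturated chain carbon bound to the aromatic nitrogen of the triazole, and that entire triazole-bearing group is what leaves in compound 4, so none of them addresses this change directly. They show only that varying that distal substituent moves this assay by modest amounts at most. With the whole group removed and nothing in the data to anchor the effect, the step for compound 4 is expected to be small to modest, most likely toward a higher number, as a 1.4-fold higher number from compound 1 to compound 4 (0.15 log units; within the scatter). Compound 4 is therefore estimated at 9000 nM, with a range from 3000 nM to 30000 nM in this assay.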

Compound 4, half-maximal inhibitory concentration: 19100 nM
Estimate against measurement, compound 4: 2.1-fold (0.33 log units) below; the measured number falls inside the stated range.
By their numbers in this assay, from the lowest: compounds 2 and 1 (each within the scatter of the next); then compounds 3 and 4 (each within the scatter of the next).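

Going by these compounds alone, replacing the whole triazole-bearing group with ethynyl, on the saturated chain carbon bound to an oxygen on an aromatic ring, gives in this assay a 3.0-fold higher number from compound 1 to compound 4 (0.48 log units; beyond the scatter) and so shows that this position is not indifferent to the change, which the earlier steps, all confined to the far end of that group, could not show. The triazole alone does not account for the lower numbers, however: compound 3 keeps it and still stands within the scatter of compound 4, while compound 1 and compound 2 stand apart from that pair, so what is attached to the triazole counts as much as the ring's presence. The data shown offer no measurement that would explain this step.

As far as these compounds go, it stays open whether the ring itself matters or only the reach of the group, and a plain longer chain or a chain ending in an amine, in place of the triazole-bearing group, would separate the two. Also open, from the compounds shown here alone, is whether a carboxylic acid on the triazole's saturated chain carbon would bring the number closer to that of compound 1 or of compound 4.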